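Replacing the 2-aminophenyl group of compound 1

The source may report more compounds than this note shows. Statements on the series, on what has been measured and on what is new or still open speak of the compounds shown alone.

compound 1 `COC(=O)C1=C(C)N=C(C)/C(=C(\O)OC)C1c1ccccc1N`: 39800 nM
compound 2 `COC(=O)C1=C(C)N=C(C)/C(=C(\O)OC)C1c1ccccc1I`: 46.8 nM
compound 3 `COC(=O)C1=C(C)N=C(C)/C(=C(\O)OC)C1c1ccccc1C(F)(F)F`: 1.51 nM
compound 4 `COC(=O)C1=C(C)N=C(C)/C(=C(\O)OC)C1c1cccc(Br)c1`: not yet measured

In a functional assay (muscle tissue) with Cavia porcellus as the target (a higher number here means that more compound is needed for the effect, a lower number that less compound is needed), compound 1 gives 39800 nM as the highest of the three numbers, so much more of it is needed than of either other compound. Compound 4 keeps the core of compound 1 and carries 3-bromophenyl in place of 2-aminophenyl on a saturated ring carbon, counted as 3-bromophenyl in place of 2-aminophenyl on a saturated ring carbon in full.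

Among the measured compounds shown here, two measured steps bear on this change, and both remove the amino group. Iodo in place of amino gives an 850-fold lower number from compound 1 to compound 2 (2.93 log units; beyond the scatter) and trifluoromethyl in place of amino gives a 26000-fold lower number from compound 1 to compound 3 (4.42 log units; beyond the scatter) as the larger of the two. The replacing group clearly matters too, since the data show a 31-fold lower number from compound 2 to compound 3 (1.49 log units; beyond the scatter) between the two replacements. Neither step is a direct precedent, however. For the measured compounds named here, no bromo compound has been measured, and no 3-substituted phenyl group appears among the three compounds. Compound 2, with 46.8 nM in this set, is taken as the closest guide. Like compound 4, it carries a halogen.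

A large step to a lower number is therefore expected, an estimated 660-fold lower number from compound 1 to compound 4 (2.82 log units; beyond the scatter) in this assay overall. For compound 4 the estimated value is 60 nM with an expected range from 10 nM to 400 nM as the likely span.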

Compound 4, half-maximal effective concentration: 1.29 nM
Compound 4: the middle estimate sits 47-fold (1.67 log units) above what was measured; measured number outside the range, below it.
By their numbers in this assay, from the lowest: compounds 4 and 3 (each within the scatter of the next); then compound 2; then compound 1.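

Among the compounds shown here, the change to 3-bromophenyl gives a 31000-fold lower number from compound 1 to compound 4 (4.49 log units; beyond the scatter) in this assay and so shows that the low numbers at this saturated ring carbon are not confined to the 2-substituted phenyl groups of the earlier compounds. Halogen alone does not settle the number, since 3-bromophenyl in place of 2-iodophenyl gives a 36-fold lower number from compound 2 to compound 4 (1.56 log units; beyond the scatter) as a further large step, while compound 3 at 1.51 nM and compound 4 at 1.29 nM lie within the scatter of each other, so the trifluoromethyl and 3-bromophenyl compounds cannot be ranked in this assay. No measurement at hand accounts for these differences.

The step from 2-iodophenyl to 3-bromophenyl alters both the halogen and where it sits on the phenyl ring, so the compounds shown cannot separate those two changes, and a 2-bromophenyl or a 3-iodophenyl compound would be needed to do that. From the compounds shown here alone, it also stays open whether 3-aminophenyl would give a number as high as that of compound 1 or whether the amino group behaves differently there.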